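Adding fluorine to the side chain of compound 2

A few compounds are considered here, and "the series" means these few. Any claim that something is new, unique, unknown or untested is made for them only; others in the source may bear on it.

In a functional assay on HL-60 cells (Homo sapiens) for cytotoxicity, read by WST assay, with a stated time of 48 h (a lower number here means a stronger inhibitor, a higher number a weaker inhibitor), compound 1 `COC[C@H](C(C)C)C(c1ccc(O)c(OC)c1)c1ccc(O)c(OC)c1` gives 72000 nM and compound 2 `COc1cc(C(c2ccc(O)c(OC)c2)[C@H](C)C(C)C)ccc1O` gives 17000 nM, the lower of these two numbers. For the measured compounds named here, the only measured step, a 4.2-fold lower number from compound 1 to compound 2 (0.63 log units; beyond the scatter), is hydrogen in place of methoxy on a saturated chain carbon. Compound 3 `COc1cc(C(c2ccc(O)c(OC)c2)[C@@H](C)[C@@H](C)CF)ccc1O` alters the chain differently: 2-(fluoromethyl)-1-methylpropyl in place of 1,2-dimethylpropyl on a saturated chain carbon bound to two aromatic carbons, with 2-(fluoromethyl)-1-methylpropyl in place of 1,2-dimethylpropyl. The measured step involved a different group, so it offers only a loose guide, and a small move towards a higher number is expected: a 1.3-fold higher number from compound 2 to compound 3 (0.11 log units; within the scatter). Compound 3 is estimated at 22000 nM, within an expected range of 9000 nM to 55000 nM.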

Compound 3, half-maximal inhibitory concentration: 38000 nM
Compound 3: middle estimate off by 1.7-fold (0.24 log units), on the low side, within the range that was stated.
By their numbers in this assay, from the lowest: compound 2; then compounds 3 and 1 (each within the scatter of the next).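

In this assay, fluorine on this side chain brings no gain: the change gives a modest move the wrong way (a 2.2-fold higher number from compound 2 to compound 3 (0.35 log units; beyond the scatter)), so compound 2 keeps the lowest number. The step between the two substituted chains stays within the scatter (a 1.9-fold lower number from compound 1 to compound 3 (0.28 log units; within the scatter)), so 2-(fluoromethyl)-1-methylpropyl and 1-(methoxymethyl)-2-methylpropyl cannot be told apart. No measurement here bears on why the numbers move.

Still open, going by these compounds, is how a hydroxymethyl, a trifluoromethyl or a longer chain would behave in this side chain, and whether any such group could reach a number lower than that of compound 2.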